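The compounds below may be only part of what the source reports. "The series", "measured", "known", "first", "only" and "open" are said of these compounds alone.

Measured in a functional assay on A549 cells (Homo sapiens) for inhibition, read by sulforhodamine B assay, with a stated time of 48 h; a higher number here means a weaker inhibitor of growth, a lower number a stronger inhibitor of growth
- compound 1 `Cc1ccc(/C=C/C(=O)/C=C(O)/C=C/c2ccc(C)o2)o1` gives > 25000 nM
- compound 2 `COc1cc(/C=C/C(=O)/C=C/c2sccc2C)cc(OC)c1OC` gives 9310 nM
- compound 3 `COc1cc(C=C(C(=O)/C=C/c2ccc(OC)c(OC)c2)C(=O)/C=C/c2ccc(OC)c(OC)c2)ccc1O` gives 530 nM

Compound 1 has the entry > 25000 nM, which is a limit of the assay and not a number. Of the two actual numbers in this assay, compound 3 holds the lower at 530 nM and sits beyond the scatter from the nearest number, that of compound 2 at 9310 nM.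

The next compound to be read is compound 4 `COc1ccc(/C=C/C(=O)C(=Cc2cccc(OC)c2OC)C(=O)/C=C/c2ccc(OC)c(OC)c2)cc1OC`, which keeps the rest of compound 3 and changes one aryl group: 2,3-dimethoxyphenyl in place of 4-hydroxy-3-methoxyphenyl on a double-bonded chain carbon bound to a double-bonded chain carbon. The change is 2,3-dimethoxyphenyl in place of 4-hydroxy-3-methoxyphenyl, on a double-bonded chain carbon bound to a double-bonded chain carbon.

Among the measured compounds shown here, no pair of measured compounds differs in one place, so the series offers no direct precedent for this swap. A modest rise in the number in this assay is expected, probably small but just beyond the scatter. The reading should stay closer to compound 3 at 530 nM than to the other measured compounds, since most of that structure is retained. The expected change is a 2.3-fold higher number from compound 3 to compound 4 (0.35 log units; beyond the scatter). The estimate for compound 4 is 1200 nM, with an expected range from 350 nM to 5000 nM.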

Compound 4, concentration for 50% growth inhibition: 670 nM
Compound 4: the middle estimate sits 1.8-fold (0.25 log units) above what was measured; low and high end bracket the measured number.
By their numbers in this assay, from the lowest: compounds 3 and 4 (each within the scatter of the next); then compound 2. At a limit, above all of these: compound 1.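

In this assay, among the compounds shown here, 2,3-dimethoxyphenyl in place of 4-hydroxy-3-methoxyphenyl on a double-bonded chain carbon bound to a double-bonded chain carbon gives the first one-place comparison, a 1.3-fold higher number from compound 3 to compound 4 (0.10 log units; within the scatter). The leaving group has 1 hydrogen-bond donor and the entering group has 0 hydrogen-bond donors, so at this place in these two compounds, that difference comes with no change that can be read beyond the scatter. No measured property at hand bears on this result, so the step stands as an observation without an explanation.

The step changes the hydroxy group and the arrangement of the methoxy groups at once, and the compounds shown do not separate these two changes or vary the other two aryl groups on this scaffold. Also open, as far as these compounds go, is whether an amine or a carboxylic acid on the aryl group at this place, or a longer chain in place of that aryl group, would keep the reading in the range of compound 3 and compound 4.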